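This account rests on a few compounds, and the source may have more. Where it says the series, first, only, none or still open, it means among the compounds named here.

In a physicochemical assay for acid dissociation, compound 2 `c1ccc(Oc2ccc3c(NCCCNCc4ccco4)ccnc3c2)cc1` gives 9.28. Among the measured compounds shown here, only one other compound has been measured there: compound 1 `FC(F)(F)c1ccc(-c2ccc3c(NCCCNCc4ccco4)ccnc3c2)cc1` gives 9.47, and the step of a number 0.19 log units lower from compound 1 to compound 2 (within the scatter) lies within the scatter. Compound 3 `COc1ccc(-c2ccc3c(NCCCNCc4ccco4)ccnc3c2)cc1` carries a further change on the shared core: 4-methoxyphenyl in place of phenoxy on an aromatic carbon. For the measured compounds named here, the single step that bears on this, from compound 1 to compound 2, was within the scatter, so no step beyond the scatter is expected here either. The expected step is a number 0.12 log units higher from compound 2 to compound 3 (within the scatter). Compound 3 is therefore estimated at 9.4, within a range from 9 to 9.8.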

Compound 3, acid dissociation constant: 9.47
The estimate for compound 3 lay 0.07 log units below the measured number, and the stated range covers the measured number.
By their numbers in this assay, from the lowest: compounds 2, 1 and 3 (each within the scatter of the next).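

In this assay, compound 3 adds a third group at this aromatic carbon of the shared core: 4-methoxyphenyl in place of phenoxy gives a number 0.19 log units higher from compound 2 to compound 3 (within the scatter), and methoxy in place of trifluoromethyl gives no change at the digits printed from compound 1 to compound 3 (within the scatter). All three groups, including two that differ only in the substituent on the phenyl ring, therefore fall within the scatter of one another. No available evidence accounts for this result. From the compounds shown here alone, whether an amine or a carboxylic acid at this position would give a step beyond the scatter remains open.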